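The source may hold more compounds than are shown below. What is called first, only, known or untested is meant among the compounds shown, and "the series" means these compounds.

Measured in a functional assay on HeLa cells (Homo sapiens) for antiproliferative activity, with a stated time of 48 h; on this read-out higher numbers stand for weaker inhibition and lower numbers for stronger inhibition:
- compound 1 `C=C(Br)C(=O)Nc1ccc(/C=C/C(=O)c2ccccc2)cc1`: 3900 nM
- compound 2 `C=C(Br)C(=O)Nc1ccc(/C=C/C(=O)c2ccc(F)cc2)cc1`: 1400 nM
- compound 3 `C=C(Br)C(=O)Nc1ccc(/C=C/C(=O)c2ccc(Cl)cc2)cc1`: 1600 nM

In this assay, compound 3 gives 1600 nM. It is level with compound 2, a 1.1-fold higher number from compound 2 to compound 3 (0.06 log units; within the scatter), and clearly under compound 1, a 2.4-fold lower number from compound 1 to compound 3 (0.39 log units; beyond the scatter). The next compound, compound 4 `C=C(Br)C(=O)Nc1ccc(/C=C/C(=O)c2ccc(Cl)c(Cl)c2)cc1`, changes the 4-chlorophenyl of compound 3 to 3,4-dichlorophenyl: chloro in place of hydrogen on an aromatic carbon. The new chloro stands ortho to a chloro group.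

Among the measured compounds shown here, two measured steps bear on this, and in both a hydrogen of compound 1 gives way to a halogen. One is a 2.4-fold lower number from compound 1 to compound 3 (0.39 log units; beyond the scatter), the other 2.8-fold lower number from compound 1 to compound 2 (0.44 log units; beyond the scatter). Both are modest, but each started from a ring with no chloro group and neither tests this aromatic carbon. A second chloro is therefore expected to give another modest lowering at most, with no change beyond the scatter still possible. The estimate amounts to a 1.6-fold lower number from compound 3 to compound 4 (0.20 log units; within the scatter), an expected step. For compound 4 the expected value is 1000 nM, with an estimated range of 450 nM to 2200 nM.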

Compound 4, half-maximal inhibitory concentration: 3200 nM
Compound 4: middle estimate off by 3.2-fold (0.51 log units), on the low side; the whole stated range lies below it.
By their numbers in this assay, from the lowest: compounds 2, 3, 4 and 1 (each within the scatter of the next, the first and the last beyond it).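

In this assay, the new chloro, ortho to a chloro group, does not give a lowering that can be told from the scatter (a 2.0-fold higher number from compound 3 to compound 4 (0.30 log units; within the scatter)). The 3,4-dichlorophenyl group also stands level with the plain phenyl (a 1.2-fold lower number from compound 1 to compound 4 (0.09 log units; within the scatter)) and separates only from 4-fluorophenyl (a 2.3-fold higher number from compound 2 to compound 4 (0.36 log units; beyond the scatter)), so the modest lowering seen with a single halogen does not carry over to a second chloro at this carbon. Nothing available here explains this result.

From the compounds shown here alone, it remains open whether this aromatic carbon would respond differently to a fluoro, a methoxy or an amine. A chloro at this carbon without the 4-chloro would show whether the carbon itself or the pairing of two chloro groups sets the outcome.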